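Aryl exchange on the amide-type nitrogen of compound 1

This account rests on a few compounds, and the source may have more. Where it says the series, first, only, none or still open, it means among the compounds named here.

Compound 1 `Fc1ccccc1NC(=S)N/N=C/c1ccc2ccccc2n1` is read in a functional assay on HeLa cells (Homo sapiens) for antiproliferative activity, read by sulforhodamine B assay, with a stated time of 72 h; a higher number here means a weaker inhibitor, a lower number a stronger inhibitor. In this assay compound 1 gives only an assay limit of > 100000 nM, not a number. That limit is the point (the limit of > 100000 nM in this assay, at which 1 of the 3 values shown sits). Two relatives with an unsubstituted nitrogen and other cores are measured as numbers: compound 2 `NC(=S)N/N=C/c1cc2cccnc2s1` gives 6290 nM in this assay, and compound 3 `NC(=S)N/N=C/c1nc2ccccc2s1` gives 5350 nM in this assay. For the measured compounds named here, no pair of measured compounds differs in a single place, so no measured step is on hand. Compound 4 `S=C(N/N=C/c1ccc2ccccc2n1)Nc1ccc(Br)cc1` differs from compound 1 by 4-bromophenyl in place of 2-fluorophenyl on an amide-type nitrogen. Compound 1 offers only a limit, so the step to compound 4 is expected to be small, with a real chance of another limit. Compound 4 is expected at 80000 nM, within 20000 nM to 200000 nM, an expected step of an at least 1.2-fold lower number from compound 1 to compound 4 (0.09 log units; that floor lies within the scatter).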

Compound 4, half-maximal inhibitory concentration: 56800 nM
The estimate for compound 4 lay 1.4-fold (0.15 log units) above the measured number; measured number inside the range.
By their numbers in this assay, from the lowest: compounds 3 and 2 (each within the scatter of the next); then compound 4. At a limit, above all of these: compound 1.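

In this assay, this position on the amide-type nitrogen now gives a measured number on the core of compound 1, with 4-bromophenyl in place of 2-fluorophenyl: an at least 1.7-fold lower number from compound 1 to compound 4 (0.24 log units; that floor lies within the scatter). No firm gain from this exchange can be claimed yet. The step remains a floor because compound 1 stands at an assay limit, not a number: the limit of > 100000 nM in this assay, at which 1 of the 4 values shown sits.

The halogen and its ring position change together, so their contributions remain unseparated. From the compounds shown here alone, how an unsubstituted phenyl, or a phenyl carrying an amine or a carboxylic acid, would read at this nitrogen remains open.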